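The compounds below may be only part of what the source reports. "The series", "measured", "known", "first", "only" and "open" are said of these compounds alone.

The three measured compounds share one core and differ only in the group on one aromatic carbon. Compound 3 `CS(=O)(=O)Nc1cccc2c1CCC2c1ncc[nH]1` carries a methanesulfonamido group there, and in a functional assay on CHO cells for agonist activity at Alpha-1A adrenergic receptor (Homo sapiens), read by FLIPR and calcium flux (a lower number here means that less compound is needed, a higher number that more compound is needed for the effect), compound 3 gives 70 nM, the lowest of the two numbers shown. Compound 2 `Cn1nccc1-c1cccc2c1CCC2c1ncc[nH]1` carries a 1-methyl-1H-pyrazol-5-yl group, and in this assay compound 2 gives 278 nM. Compound 1 `Cn1ccc(-c2cccc3c2CCC3c2ncc[nH]2)n1` carries a 1-methyl-1H-pyrazol-3-yl group, and in this assay compound 1 reaches only the limit of the assay, > 1300 nM.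

Compound 4 `Cn1cc(-c2cccc3c2CCC3c2ncc[nH]2)cn1` differs from compound 3 in one place: 1-methyl-1H-pyrazol-4-yl in place of methanesulfonamido on an aromatic carbon. Going by the values given here, two measured steps bear on this exchange, read in reverse: an at least 18-fold lower number from compound 1 to compound 3 (1.26 log units; beyond the scatter) and a 4.0-fold lower number from compound 2 to compound 3 (0.60 log units; beyond the scatter). In both, the methanesulfonamido compound gave the lower number than its pyrazolyl partner. The step from compound 3 to compound 4 is therefore expected to raise the number in this assay by a modest to large amount, a 5.7-fold higher number from compound 3 to compound 4 (0.76 log units; beyond the scatter). Compound 4 is expected to give about 400 nM in this assay, within a range from 150 nM to 1500 nM.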

Compound 4, half-maximal effective concentration: > 2900 nM
Compound 4 was reported as a limit (the forecaster's own chance of this, stated with the estimate: 15%); at least 7.2-fold (0.86 log units) between middle value and limit.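

In this assay, the choice among the three methylpyrazolyl groups on this aromatic carbon carries a large effect, with an at least 10-fold higher number from compound 2 to compound 4 (1.01 log units; beyond the scatter), and of the three only the 1-methyl-1H-pyrazol-5-yl group gives a number that is not a limit. Against methanesulfonamido the exchange gives an at least 41-fold higher number from compound 3 to compound 4 (1.61 log units; beyond the scatter), so a third pyrazolyl group now falls short of the methanesulfonamido compound in this series. Compound 4 stands at a limit of the assay, not at a number: the limit of > 2900 nM in this assay, at which 1 of the 4 values shown sits.

From the compounds shown here alone, compound 1 and compound 4 both sit at limits, so their order stays open and the step between them cannot be read. Also open, going by these compounds, is how a simple amine, an acetamido group or a pyrazolyl group without its methyl would behave on this aromatic carbon.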